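Permeability after swapping the sulfonyl chain for an aromatic ring

This account rests on a few compounds, and the source may have more. Where it says the series, first, only, none or still open, it means among the compounds named here.

Compound 2 `CC(C)NC(=O)NCCS(=O)(=O)NC(=O)c1ccc(Nc2nc(NC3(c4ccc(Cl)cc4)CC3)nc(OCC(F)(F)F)n2)cc1` and compound 1 `CC(C)NCCS(=O)(=O)NC(=O)c1ccc(Nc2nc(NC3(c4ccc(Cl)cc4)CC3)nc(OCC(F)(F)F)n2)cc1` differ in a single place, and the step between them says where. In a physicochemical assay for permeability, using PAMPA, at pH 7.4 (a lower number here means that the compound crosses the layer more slowly, a higher number that the compound crosses the layer faster), compound 1 gives 45 nm/s, and compound 2 gives 45 nm/s, so that step no change at the digits printed from compound 1 to compound 2 (within the scatter) left the number where it was. Compound 3 `Cc1ccccc1S(=O)(=O)NC(=O)c1ccc(Nc2nc(NC3(c4ccc(Cl)cc4)CC3)nc(OCC(F)(F)F)n2)cc1` goes further: 2-methylphenyl in place of 2-((isopropylcarbamoyl)amino)ethyl on a sulfonyl sulfur. Among the measured compounds shown here, the single measured step only exchanged one end of the chain for another, whereas here the whole chain leaves and a ring without hydrogen-bond donors or acceptors enters, so that step gives no direct guide. Given that the change removes the two hydrogen-bond donors and the one acceptor counted above, compound 3 is expected to cross faster, by about a 2.9-fold higher number from compound 2 to compound 3 (0.46 log units; beyond the scatter). The estimate for compound 3 in this assay is 130 nm/s, with a range from 45 nm/s to 400 nm/s.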

Compound 3, apparent permeability: 265 nm/s
The estimate for compound 3 lay 2.0-fold (0.31 log units) below the measured number, and the stated range covers the measured number.
By their numbers in this assay, from the lowest: compounds 1 and 2 (each within the scatter of the next); then compound 3.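

Swapping one chain end for another left this assay unchanged, but this position is not insensitive to every change. With 2-methylphenyl on the sulfonyl sulfur in place of 2-((isopropylcarbamoyl)amino)ethyl, the result is a 5.9-fold higher number from compound 2 to compound 3 (0.77 log units; beyond the scatter) in this assay, and in place of 2-(isopropylamino)ethyl it is a 5.9-fold higher number from compound 1 to compound 3 (0.77 log units; beyond the scatter) by the same amount. The swap changes the ring content and the hydrogen-bond donors and acceptor together, and nothing shown here gives a measured explanation for the rise.

The compounds shown leave open whether the ring, its methyl group or the loss of the chain's donors and acceptor carries the step. Plain phenyl, cyclohexyl or a short unbranched alkyl chain on the sulfonyl sulfur would help separate these possibilities.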